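Branching the Ester Chain and Toxicity on Vero Cells

The source may report more compounds than this note shows. Statements on the series, on what has been measured and on what is new or still open speak of the compounds shown alone.

Compound 1: `CCCCOC(=O)C(O)Cn1cnc2c(N)ncnc21` gives 200 ug/mL in a functional assay on Vero cells (Chlorocebus sabaeus) for cytotoxicity; on this read-out lower numbers stand for higher toxicity in this test and higher numbers for lower toxicity in this test.
Compound 2: `CC(C)COC(=O)C(O)Cn1cnc2c(N)ncnc21` gives > 400 ug/mL in this assay; that is a limit of the assay, not a number.
Compound 3: `CC(C)(C)OC(=O)C(O)Cn1cnc2c(N)ncnc21` gives > 400 ug/mL in this assay; that too is a limit.

Among the measured compounds shown here, compound 1 is thus the only compound with an actual number; the other two sit at the limit of > 400 ug/mL in this assay, at which 2 of the 3 values shown sit. Compound 4, `CCC(C)OC(=O)C(O)Cn1cnc2c(N)ncnc21`, has not yet been measured. It differs from compound 1 by sec-butyl in place of butyl on an oxygen next to a carbonyl group. For the measured compounds named here, two measured steps bear on this change, since both also replace the straight chain of compound 1 with a branched one: an at least 2.0-fold higher number from compound 1 to compound 2 (0.30 log units; that floor lies within the scatter) and an at least 2.0-fold higher number from compound 1 to compound 3 (0.30 log units; that floor lies within the scatter). Both point the same way, towards a higher number, though each rests on a limit and its floor lies within the scatter. Compound 4 is therefore expected to give a higher number than compound 1, and it may well reach the limit itself; the step of a 2.0-fold higher number from compound 1 to compound 4 (0.30 log units; within the scatter) is the estimate. For compound 4 the estimate is 400 ug/mL, within 200 ug/mL to 800 ug/mL.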

Compound 4, minimum cytotoxic concentration: > 400 ug/mL
Compound 4 was reported as a limit (the forecaster's own chance of this, stated with the estimate: 60%); the middle value sits exactly at the limit.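

Butyl and sec-butyl carry the same atoms joined differently, and in this assay this change gives an at least 2.0-fold higher number from compound 1 to compound 4 (0.30 log units; that floor lies within the scatter). Among the compounds shown here, a third branched chain therefore ends up at the limit, leaving compound 1, with its straight butyl chain, as the only compound with an actual number: the limit of > 400 ug/mL in this assay, at which 3 of the 4 values shown sit. The steps among compound 2, compound 3 and compound 4 cannot be read, as each joins two limits, so the branched chains cannot be ranked against one another.

From the compounds shown here alone, the true values of the branched esters remain unknown, and so does whether the straight and branched chains differ by more than the usual scatter. Also open, going by these compounds, is whether a longer chain such as hexyl, a cyclohexyl group or a free carboxylic acid in place of the ester would give an actual number in this assay.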